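Hydroxy for hydrogen on a bridging carbon, repeated

The source may report more compounds than this note shows. Statements on the series, on what has been measured and on what is new or still open speak of the compounds shown alone.

The shared core, unbroken here, differs between compound 1 `CCn1ccc2cc(Cc3cc(OC)c(OC)c(OC)c3)ccc21` and compound 3 `COc1ccc(Cc2ccc3c(ccn3C)c2)c(OC)c1OC`; that difference between the two cores is not broken down. In a functional assay on HeLa cells (Homo sapiens) for cytotoxicity, read by XTT assay, with a stated time of 72 h (on this read-out lower numbers stand for stronger inhibition and higher numbers for weaker inhibition), compound 1 gives 17 nM, and compound 3 gives 240 nM. Compound 2 `COc1ccc(C(O)c2ccc3c(ccn3C)c2)c(OC)c1OC` differs from compound 3 by a single change, (hydroxy in place of hydrogen on a saturated chain carbon bound to two aromatic carbons). In this assay compound 2 gives 2500 nM, so that a 10-fold higher number from compound 3 to compound 2 (1.02 log units; beyond the scatter).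

Compound 4 `CCn1ccc2cc(C(O)c3cc(OC)c(OC)c(OC)c3)ccc21` stands to compound 1 as compound 2 stands to compound 3: the same change, (hydroxy in place of hydrogen on a saturated chain carbon bound to two aromatic carbons), at the same place. It has not yet been measured in this assay. Because a 10-fold higher number from compound 3 to compound 2 (1.02 log units; beyond the scatter) was large and lay beyond the scatter, the account expects a step of similar size for compound 4, and estimates a 10-fold higher number from compound 1 to compound 4 (1.00 log units; beyond the scatter). Among the measured compounds shown here, the expectation rests on that single earlier step only, and on no other pair, since the second change here is the sole repeat. For compound 4 in this assay the estimated value is 170 nM, between 60 nM and 500 nM.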

Compound 4, half-maximal inhibitory concentration: < 1000 nM
Compound 4 was reported as a limit; the forecaster's own chance of this, stated with the estimate: 0%; the middle value is on the limit's open side.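

In this assay, among the compounds shown here, compound 4 is reported as the limit < 1000 nM and not as a number, so no step from compound 1 to compound 4 can be read. The compounds shown leave open whether hydroxy in place of hydrogen on a saturated chain carbon bound to two aromatic carbons changes the number on the core of compound 1 as it does on the core of compound 3.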